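Trimming the alkyl group on the amide-type nitrogen

The source may hold more compounds than are shown below. What is called first, only, known or untested is meant among the compounds shown, and "the series" means these compounds.

Compound 2 `CCNC(=O)N1CC1C#N` gives 10000 nM in a functional assay on MCF7 cells (Homo sapiens) for inhibition (a higher number here means a weaker inhibitor, a lower number a stronger inhibitor), the lowest of the two numbers recorded so far. Its nearest neighbour is compound 1 `CC(C)(C)NC(=O)N1CC1C#N`, which in this assay gives 120000 nM. Going by the values given here, the single measured step between them, a 12-fold lower number from compound 1 to compound 2 (1.08 log units; beyond the scatter), shows that shortening the group on the amide-type nitrogen lowered the number well beyond the scatter. Compound 3 `CNC(=O)N1CC1C#N` continues in that direction: hydrogen in place of methyl on a saturated chain carbon bound to an amide-type nitrogen, so ethylamino becomes methylamino. This change removes less than the step from compound 1 to compound 2 removed, so a smaller effect than a 12-fold lower number from compound 1 to compound 2 (1.08 log units; beyond the scatter) is expected, in the same direction or possibly none beyond the scatter. Compound 3 is therefore estimated at 7000 nM in this assay, with a range from 2500 nM to 25000 nM, corresponding to an expected step of a 1.4-fold lower number from compound 2 to compound 3 (0.15 log units; within the scatter).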

Compound 3, half-maximal inhibitory concentration: 18000 nM
The estimate for compound 3 lay 2.6-fold (0.41 log units) below the measured number, and the stated range covers the measured number.
By their numbers in this assay, from the lowest: compounds 2 and 3 (each within the scatter of the next); then compound 1.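

Replacing methyl with hydrogen on the saturated chain carbon bound to an amide-type nitrogen gives a 1.8-fold higher number from compound 2 to compound 3 (0.26 log units; within the scatter) in this assay, so shortening ethyl to methyl brings no change that can be told from the scatter, something the earlier step alone could not show. Methyl in place of tert-butyl still gives a 6.7-fold lower number from compound 1 to compound 3 (0.82 log units; beyond the scatter), so among these three compounds the only differences beyond the scatter are those from tert-butyl, while ethyl and methyl cannot be separated. Nothing in the information at hand accounts for these numbers.

As far as these compounds go, whether a longer chain such as propyl, or a branched group such as isopropyl, would fall with ethyl and methyl or with tert-butyl remains open. Also open, from the compounds shown here alone, is how a chain carrying a hydroxyl or an amine would compare.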